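Swapping the aryl amide for a cysteine ester

A few compounds are considered here, and "the series" means these few. Any claim that something is new, unique, unknown or untested is made for them only; others in the source may bear on it.

The three measured compounds share one core and differ only in the group on the amide-type nitrogen. In a functional assay on CLL cells (Homo sapiens) for cytotoxicity, read by MTT assay, with a stated time of 48 h (a higher number here means that more compound is needed for the effect, a lower number that less compound is needed), compound 1 `C=C(CC)C(=O)c1ccc(OCC(=O)Nc2ccc(C(N)=O)cc2)c(Cl)c1Cl` gives 3700 nM, compound 2 `C=C(CC)C(=O)c1ccc(OCC(=O)Nc2ccc(C(=O)O)cn2)c(Cl)c1Cl` gives 14900 nM, and compound 3 `C=C(CC)C(=O)c1ccc(OCC(=O)Nc2cccc(C(=O)O)c2)c(Cl)c1Cl` gives 20600 nM. Compound 3 stands at the highest of the three numbers: the step of a 5.6-fold higher number from compound 1 to compound 3 (0.75 log units; beyond the scatter) and the step of a 4.0-fold higher number from compound 1 to compound 2 (0.60 log units; beyond the scatter) are both beyond the scatter, while the step of a 1.4-fold higher number from compound 2 to compound 3 (0.14 log units; within the scatter) is within it, so compound 2 and compound 3 cannot be ordered against each other.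

Compound 4 `C=C(CC)C(=O)c1ccc(OCC(=O)NC(CS)C(=O)OCC)c(Cl)c1Cl` follows from compound 3 by the change (1-(ethoxycarbonyl)-2-sulfanylethyl in place of 3-carboxyphenyl on an amide-type nitrogen). The measured steps all exchange one aromatic group for another on that nitrogen; none of them bears on the entry of a group with no ring, so the size and direction of the step in this assay cannot be read from them. The whole measured range is narrow, which argues against expecting a large move. Compound 4 is therefore expected to give about 10000 nM, with a range from 2500 nM to 40000 nM; this estimate corresponds to an expected step of a 2.1-fold lower number from compound 3 to compound 4 (0.31 log units; beyond the scatter).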

Compound 4, half-maximal effective concentration: 4800 nM
Estimate against measurement, compound 4: 2.1-fold (0.32 log units) above, and the stated range covers the measured number.
By their numbers in this assay, from the lowest: compounds 1 and 4 (each within the scatter of the next); then compounds 2 and 3 (each within the scatter of the next).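

In this assay the 1-(ethoxycarbonyl)-2-sulfanylethyl group on the amide-type nitrogen gives a 4.3-fold lower number from compound 3 to compound 4 (0.63 log units; beyond the scatter) and a 3.1-fold lower number from compound 2 to compound 4 (0.49 log units; beyond the scatter) in a change that removes the aromatic ring, so a group with no ring can take this place and an aromatic ring on this nitrogen is not required for the lower numbers seen here. Within the data shown here, the further comparison shows a 1.3-fold higher number from compound 1 to compound 4 (0.11 log units; within the scatter) and leaves the ringless group and 4-carbamoylphenyl unordered, so the four compounds now form two sets: compounds 2 and 3, whose groups carry a carboxylic acid, have the higher numbers, while compounds 1 and 4, whose groups carry none, have the lower numbers, with no compound here going against this split. Nothing given here accounts for these steps.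

Which part of the new group matters remains open: the compounds shown do not tell how a carboxylic acid in place of the ethyl ester, or a hydroxyl in place of the sulfanyl group, would fare. They also leave open whether a longer chain or a simple amine on this nitrogen would stay with compounds 1 and 4 or with compounds 2 and 3.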